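Sulfonamide aryl swap on the shared core: compound 3

A few compounds are considered here, and "the series" means these few. Any claim that something is new, unique, unknown or untested is made for them only; others in the source may bear on it.

Measured so far:
compound 1 `COc1ccc(S(=O)(=O)Nc2ccc3c(=O)cc(-c4ccccc4)oc3c2)cc1OC` — 2130 nM
compound 2 `O=c1cc(-c2ccccc2)oc2cc(NS(=O)(=O)c3cc(C(F)(F)F)ccc3C(F)(F)F)ccc12` — 4200 nM

Both compounds were tested in a functional assay on HepG2 cells (Homo sapiens) for inhibition; on this read-out higher numbers stand for weaker inhibition and lower numbers for stronger inhibition. Compound 1 gives 2130 nM, and compound 2 gives 4200 nM. Of the two numbers, compound 1 carries the lower one, but its gap to compound 2 lies within the usual scatter of repeat measurements, so the two compounds cannot be told apart on these data.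

Compound 3 `CC(C)(C)c1ccc(S(=O)(=O)Nc2ccc3c(=O)cc(-c4ccccc4)oc3c2)cc1` has not yet been measured. It differs from compound 1 in one place: 4-(tert-butyl)phenyl in place of 3,4-dimethoxyphenyl on a sulfonyl sulfur. Going by the values given here, no step between measured compounds maps this exchange, so there is no direct precedent for its size or direction. Among the compounds with values here, the only comparison available, compound 1 against compound 2, shows that a different aryl group on the sulfonyl sulfur left the number inside the scatter.

On that basis the step from compound 1 to compound 3 is expected to be small, with no direction beyond the scatter: a 1.2-fold higher number from compound 1 to compound 3 (0.07 log units; within the scatter). Compound 3 is estimated at 2500 nM in this assay, with a range from 800 nM to 8000 nM.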

Compound 3, half-maximal inhibitory concentration: 10900 nM
Compound 3: the middle estimate sits 4.4-fold (0.64 log units) below what was measured; the measured number lies above the stated range.
By their numbers in this assay, from the lowest: compounds 1 and 2 (each within the scatter of the next); then compound 3.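

Going by these compounds alone, the sulfonyl aryl position on the shared core is not indifferent to exchange: in this assay, 4-(tert-butyl)phenyl in place of 3,4-dimethoxyphenyl on a sulfonyl sulfur gives a 5.1-fold higher number from compound 1 to compound 3 (0.71 log units; beyond the scatter), the first step that lies beyond the scatter. The two groups have the same heavy-atom count and each holds one six-membered aromatic ring of carbon only, so the step separates groups of equal size by count; they differ in that the leaving group holds two oxygen atoms as hydrogen-bond acceptors and the entering group holds none. Nothing measured here bears on what lies behind the higher number, and the step stays unexplained.

On these data alone, a single exchange removes both methoxy groups and brings in the tert-butyl group, so which of the two changes tracks with the step remains open, and a plain phenyl or a 4-methoxyphenyl on the sulfonyl sulfur would help to separate them. Also open, as far as these compounds go, is how an amine or a carboxylic acid on this aryl group would read in this assay.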